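A few compounds are considered here, and "the series" means these few. Any claim that something is new, unique, unknown or untested is made for them only; others in the source may bear on it.

Three compounds of one shared core were tested in a functional assay on HeLa cells (Homo sapiens) for cytotoxicity, read by WST assay, with a stated time of 48 h; on this read-out higher numbers stand for weaker inhibition and lower numbers for stronger inhibition. Compound 1, `Oc1ccccc1/C=C/C[C@H]1C[C@@H]([C@@H](O)c2ccccc2)CO[C@@H]1c1ccccc1`, gives 21800 nM. Compound 2, `COc1ccc([C@H]2OC[C@H]([C@@H](O)c3ccc(OC)c(OC)c3)C[C@@H]2C/C=C/c2ccccc2)cc1OC`, gives 14800 nM. Compound 3, `COc1ccc([C@H](O)[C@H]2CO[C@@H](c3ccc(OC)c(OC)c3)[C@H](C/C=C/c3ccc(OC)c(OC)c3)C2)cc1`, gives 32200 nM. Among these three numbers compound 1 stands second highest; its nearest neighbour is compound 2, and its furthest is compound 3, yet both of those gaps lie within the usual scatter of this assay, so the three values cannot be placed in any order of strength. Compound 4, `O[C@@H](c1ccccc1)[C@H]1CO[C@H](c2ccccc2)[C@@H](C/C=C/c2ccncc2)C1`, has not been measured yet. It departs from compound 1 in one place: pyridin-4-yl in place of 2-hydroxyphenyl on a double-bonded chain carbon bound to a double-bonded chain carbon. Going by the values given here, no pair of the measured compounds differs in exactly this way, so the effect of swapping a hydroxyphenyl for a pyridinyl group on the chain is untested here. Since the three measured values sit close together despite their differences in substitution, the step from compound 1 to compound 4 is expected to be small, in either direction, and most likely not beyond the scatter, so that a 1.0-fold higher number from compound 1 to compound 4 (0.00 log units; within the scatter) is the estimated step. Compound 4 is therefore expected to give about 22000 nM in this assay, with a plausible range from 8000 nM to 60000 nM.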

Compound 4, half-maximal inhibitory concentration: > 100000 nM
Compound 4 gave a limit, no number; the forecaster's own chance of this, stated with the estimate: 15%; middle value at least 4.5-fold (0.65 log units) away from the limit.
By their numbers in this assay, from the lowest: compounds 2, 1 and 3 (each within the scatter of the next, the first and the last beyond it). At a limit, above all of these: compound 4.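

In this assay compound 4 gives > 100000 nM, which is a limit of the assay and not a number. Pyridin-4-yl in place of 2-hydroxyphenyl on a double-bonded chain carbon bound to a double-bonded chain carbon gives an at least 4.5-fold higher number from compound 1 to compound 4 (0.66 log units; beyond the scatter); this is the first change in the series that can be read on its own, and it shows that the group carried at this place on the chain can shift the read-out beyond the scatter, which the earlier compounds, differing from one another in more than one place, could not show. The step gives only a lower bound on the size of the change, and its full size stays unknown because compound 4 sits at a limit: the limit of > 100000 nM in this assay, at which 1 of the 4 values shown sits.

The swap removes the hydroxyl and brings in the ring nitrogen in a single step, and the compounds shown do not separate these two parts of the change. As far as these compounds go, how an aminophenyl group or a carboxylic acid would read at the same place on the chain of compound 1 also stays open.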